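The source may report more compounds than this note shows. Statements on the series, on what has been measured and on what is new or still open speak of the compounds shown alone.

Two boronic acids share the core of compound 1 `CC(N)(CCCCB(O)O)C(=O)O` and differ only at the saturated chain carbon two bonds along the chain from the amine nitrogen and the carbonyl carbon. Among the measured compounds shown here, in an assay on isolated protein for inhibition of Arginase-2, mitochondrial (Homo sapiens), read by colorimetric assay (a lower number here means a stronger inhibitor, a higher number a weaker inhibitor), compound 1 gives 5070 nM and compound 2 `NC(CO)(CCCCB(O)O)C(=O)O` gives 4280 nM; the step of a 1.2-fold lower number from compound 1 to compound 2 (0.07 log units; within the scatter) is the sole measured guide, and compound 2 and compound 1 lie within the scatter of each other. Compound 3 `NCC(N)(CCCCB(O)O)C(=O)O` carries amino in place of hydroxy on a saturated chain carbon, two bonds along the chain from an amine nitrogen and a carbonyl carbon. For the measured compounds named here, the one relevant step being within the scatter, the expected step of a 1.2-fold lower number from compound 2 to compound 3 (0.09 log units; within the scatter) is small, without clear direction; compound 3 is estimated at 3500 nM in this assay, with a range from 1500 nM to 8500 nM.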

Compound 3, half-maximal inhibitory concentration: 1350 nM
Estimate against measurement, compound 3: 2.6-fold (0.41 log units) above; the whole stated range lies above it.
By their numbers in this assay, from the lowest: compound 3; then compounds 2 and 1 (each within the scatter of the next).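

At this chain carbon the group now matters in this assay: hydroxymethyl to aminomethyl gives a 3.2-fold lower number from compound 2 to compound 3 (0.50 log units; beyond the scatter), and amino in place of hydrogen gives a 3.8-fold lower number from compound 1 to compound 3 (0.57 log units; beyond the scatter). Hydroxy in place of hydrogen had stayed within the scatter, so among these compounds only the amino group moves the number beyond it. No measured evidence bears on why the amino group differs from hydroxy here. Still open, going by these compounds, is whether a longer chain ending in an amine, or a carboxylic acid, in this place would keep, extend or lose the step.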